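The source may report more compounds than this note shows. Statements on the series, on what has been measured and on what is new or still open speak of the compounds shown alone.

Compound 1 `C/C(=N\Nc1nc(-c2ccccc2)cs1)c1cc2ccccc2o1`: 41700 nM
Compound 2 `CCOC(=O)Cc1csc(N/N=C(\C)c2cc3ccccc3o2)n1`: 36800 nM

In an ADME assay on WI-38 cells (Homo sapiens) for cytotoxicity, read by MTT assay (on this read-out lower numbers stand for stronger inhibition and higher numbers for weaker inhibition), compound 2 gives 36800 nM, a number that sits within the scatter of compound 1, so the two cannot be told apart. Compound 3 `C/C(=N\Nc1nc(C)cs1)c1cc2ccccc2o1` differs from compound 2 by hydrogen in place of ethoxycarbonyl on a saturated chain carbon bound to an aromatic carbon. For the measured compounds named here, the only measured step, a 1.1-fold lower number from compound 1 to compound 2 (0.05 log units; within the scatter), changed the same side group and stayed within the scatter. On that single step no movement beyond the scatter is expected here either. Compound 3 is therefore estimated at 40000 nM, with a range from 15000 nM to 110000 nM, which would mean a 1.1-fold higher number from compound 2 to compound 3 (0.04 log units; within the scatter).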

Compound 3, half-maximal inhibitory concentration: 44300 nM
Estimate against measurement, compound 3: 1.1-fold (0.04 log units) below; measured number inside the range.
By their numbers in this assay, from the lowest: compounds 2, 1 and 3 (each within the scatter of the next).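

With the ethoxycarbonyl gone, only a methyl remains on this aromatic carbon, yet the number in this assay stays within the scatter of both earlier compounds (a 1.2-fold higher number from compound 2 to compound 3 (0.08 log units; within the scatter)) and (a 1.1-fold higher number from compound 1 to compound 3 (0.03 log units; within the scatter)). Phenyl, (ethoxycarbonyl)methyl and methyl at this place therefore cannot be told apart, so this read-out does not respond to any of these three groups. Going by these compounds, whether an amine or a carboxylic acid here would move the number beyond the scatter remains open, as do changes elsewhere on the shared core. Nothing available explains this flat result.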